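The compounds below may be only part of what the source reports. "The series", "measured", "known", "first", "only" and "open" are said of these compounds alone.

Measured so far:
- Compound 1 `O=C(COc1ccccc1C(=O)/C=C/c1ccc(Cl)cc1)NCCNc1ccnc2cc(Cl)ccc12`: 4980 nM
- Compound 2 `CC(=O)c1ccccc1OCC(=O)NCCNc1ccnc2cc(Cl)ccc12`: 106000 nM
- Compound 3 `COc1cc(OC)c(OC)cc1/C=C/C(=O)NCCNc1ccnc2cc(Cl)ccc12`: 16100 nM

These three compounds share a common core and were tested in an ADME assay on Vero cells (Chlorocebus sabaeus) for cytotoxicity, read by MTT assay, with a stated time of 72 h; a lower number here means that less compound is tolerated, a higher number that more compound is tolerated. Compound 1 gives the lowest number of the three: compound 3 sits closest to it, and compound 2 furthest away, both beyond the scatter. Going by the values given here, the one step that is directly comparable, a 21-fold higher number from compound 1 to compound 2 (1.33 log units; beyond the scatter), shows that removing the extended double-bonded chain from the carbonyl carbon makes the compound far better tolerated.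

Compound 4 `COc1cc(OC)c(OC)cc1/C=C/C(=O)c1ccccc1OCC(=O)NCCNc1ccnc2cc(Cl)ccc12` keeps that chain and changes only its far end: 2,4,5-trimethoxyphenyl in place of 4-chlorophenyl on a double-bonded chain carbon bound to a double-bonded chain carbon. Among the compounds with values here, no measured step describes exactly this swap. Within the data shown here, the only hint comes from compound 3, which carries the 2,4,5-trimethoxyphenyl group on a similar chain and gives 16100 nM, somewhat above compound 1. The step of a 1.5-fold higher number from compound 1 to compound 4 (0.18 log units; within the scatter) is therefore expected to be small, possibly toward a higher number, and likely within or only just beyond the scatter. Compound 4 is estimated at 7500 nM, with a range from 2500 nM to 25000 nM.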

Compound 4, half-maximal cytotoxic concentration: 12300 nM
The estimate for compound 4 lay 1.6-fold (0.21 log units) below the measured number, within the range that was stated.
By their numbers in this assay, from the lowest: compound 1; then compounds 4 and 3 (each within the scatter of the next); then compound 2.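

In this assay the far end of the chain proves not to be a silent position: replacing 4-chlorophenyl with 2,4,5-trimethoxyphenyl on a double-bonded chain carbon bound to a double-bonded chain carbon gives a modest rise (a 2.5-fold higher number from compound 1 to compound 4 (0.39 log units; beyond the scatter)) that lies beyond the scatter. This change moves the number less than replacing the whole 2-(4-chlorophenyl)ethenyl group with methyl (a 21-fold higher number from compound 1 to compound 2 (1.33 log units; beyond the scatter)), so in these compounds, swapping the ring at the end of the chain matters less than removing the chain and its ring altogether. No measurement shown here explains why the swap raises the number.

From the compounds shown here alone, the swap removes a chlorine and adds three methoxy groups at once, so the contribution of each remains unknown. An unsubstituted phenyl ring or a 4-methoxyphenyl ring at this place would help separate them, and a 4-dimethylaminophenyl ring would show how an amine behaves there.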